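The compounds below may be only part of what the source reports. "The series", "measured", "known", "first", "only" and "open" are said of these compounds alone.

The measured compounds:
compound 1, `CN1C/C(=C\c2cccnc2)C(=O)/C(=C/c2ccccc2F)C1`, 4810 nM
compound 2, `CN1C/C(=C\c2cccnc2)C(=O)/C(=C/c2ccccc2C(F)(F)F)C1`, 2550 nM
compound 3, `O=C1/C(=C/c2ccncc2)CN(S(=O)(=O)c2ccc(C(F)(F)F)cc2)C/C1=C\c1ccccc1F`, 4030 nM

In a functional assay on HepG2 cells (Homo sapiens) for cytotoxicity, read by MTT assay, with a stated time of 24 h (on this read-out lower numbers stand for stronger inhibition and higher numbers for weaker inhibition), compound 2 gives 2550 nM and compound 1 gives 4810 nM. The two share one core and differ only in fluoro in place of trifluoromethyl on an aromatic carbon, and that change made a 1.9-fold higher number from compound 2 to compound 1 (0.28 log units; within the scatter). Compound 3, built on a different core, gives 4030 nM in this assay; its number lies within the scatter of both compound 1 and compound 2. The difference between the core of compound 3 and the core of compound 2 is not broken down here.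

Compound 4, `O=C1/C(=C/c2ccncc2)CN(S(=O)(=O)c2ccc(F)cc2)C/C1=C\c1ccccc1F`, has not yet been measured. It differs from compound 3 by fluoro in place of trifluoromethyl on an aromatic carbon. Within the data shown here, this is the same kind of change as the one from compound 2 to compound 1, though not the same: in compound 2 the trifluoromethyl stands ortho to a large group, while in compound 3 it stands para to a large group.

Among the measured compounds shown here, since the only precedent, the step from compound 2 to compound 1, stayed within the scatter, compound 4 is expected to show a similarly small step, a 1.5-fold higher number from compound 3 to compound 4 (0.17 log units; within the scatter), in this assay. The estimate for compound 4 is therefore 6000 nM, with a likely range from 3000 nM to 12000 nM.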

Compound 4, half-maximal inhibitory concentration: 20300 nM
The estimate for compound 4 lay 3.4-fold (0.53 log units) below the measured number; the whole stated range lies below it.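

In this assay, putting fluoro in place of trifluoromethyl on the core of compound 3 gave a 5.0-fold higher number from compound 3 to compound 4 (0.70 log units; beyond the scatter), a modest step but one that clears the usual scatter. The change therefore did not carry its size over from one core to the other, and a step read on one core was a poor guide to the step on the other: the same change on two cores in this assay, a 1.9-fold higher number (0.28 log units; within the scatter) from compound 2 to compound 1 and a 5.0-fold higher number (0.70 log units; beyond the scatter) from compound 3 to compound 4, 2.7-fold (0.43 log units) apart, beyond the scatter of two such steps. This shows that, in these four compounds, the outcome of the swap depends on its setting, but it does not show what in that setting matters, since the two pairs differ both in their cores and in where the group stands, and two steps cannot separate these or give a rule for the wider series.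

The compounds shown leave open whether another group in the same place, such as chloro, methoxy or a nitrile, would give a number closer to that of compound 3 or to that of compound 4. They also leave open how large the step from trifluoromethyl to fluoro would be on a third core, which would show whether either of the two steps seen so far is the more typical.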